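A few compounds are considered here, and "the series" means these few. Any claim that something is new, unique, unknown or untested is made for them only; others in the source may bear on it.

Measured compounds:
compound 1, `Clc1cccc(-c2nc3sccn3c2/C=N/OCc2ccc(Cl)c(Cl)c2)c1`, 1100 nM in an assay on HepG2 cells for agonist activity at nuclear receptor subfamily 1 group I member 3 (Homo sapiens), read by a luciferase reporter, with a stated time of 23 h; a lower number here means that less compound is needed, a higher number that more compound is needed for the effect
compound 2, `Clc1ccc(CO/N=C/c2c(-c3ccccc3)nc3sccn23)cc1Cl`, 580 nM in this assay

Among the measured compounds shown here, compound 2 gives the lowest of the two numbers so far, yet its nearest neighbour is compound 1, and the one step that joins them, a 1.9-fold lower number from compound 1 to compound 2 (0.28 log units; within the scatter), stays within the scatter, so no real order between the two can be claimed.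

The next step leads from compound 2 to compound 3, `Clc1ccc(CO/N=C/c2c(-c3ccc(C4CCCCC4)cc3)nc3sccn23)cc1Cl`. The change is cyclohexyl in place of hydrogen on an aromatic carbon. For the measured compounds named here, no measured step bears on this kind of change: the only step known, from compound 1 to compound 2, removes a chloro group and is itself within the scatter, so it gives no guidance on adding a cyclohexyl group.

With nothing to go on, compound 3 is expected to land near compound 2, with a wide range, so that a 1.5-fold lower number from compound 2 to compound 3 (0.16 log units; within the scatter) is expected. The estimate for compound 3 in this assay is 400 nM, between 80 nM and 2000 nM.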

Compound 3, half-maximal effective concentration: > 100000 nM
Compound 3: a limit, no number (the forecaster's own chance of this, stated with the estimate: 10%); at least 250-fold (2.39 log units) between middle value and limit.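

Placing cyclohexyl on this aromatic carbon, para to a large group, gives an at least 170-fold higher number from compound 2 to compound 3 (2.23 log units; beyond the scatter). The only earlier step, hydrogen in place of chloro on an aromatic carbon, a 1.9-fold lower number from compound 1 to compound 2 (0.28 log units; within the scatter), stayed within the scatter, so the series had shown no change of this size until now. Compound 3 gives only a limit, not a number, in this assay: the limit of > 100000 nM in this assay, at which 1 of the 3 values shown sits.

As far as these compounds go, how far the result reaches beyond that limit stays open, and so does whether it belongs to cyclohexyl alone or to substitution at this carbon in general. A methyl group, a methoxy group, an amine or a carboxylic acid on the same carbon would separate these readings, since cyclohexyl is the only group shown there.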